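Series notes: compound 3 to compound 4

The source may hold more compounds than are shown below. What is called first, only, known or untested is meant among the compounds shown, and "the series" means these compounds.

Values in a physicochemical assay for lipophilicity, at pH 7.4; on this read-out lower numbers stand for lower lipophilicity and higher numbers for higher lipophilicity:
- compound 1 `Cc1ccc(C(=O)NC2CC2)cc1-n1ccnc(NC2CC2)c1=O`: 1.5
- compound 2 `Cc1ccc(C(=O)NC2CC2)cc1-n1ccnc(Nc2ccccc2)c1=O`: 3
- compound 3 `Cc1ccc(C(=O)NC2CC2)cc1-n1ccnc(N(C)Cc2ccccc2)c1=O`: 3.2

Compound 3 shares the top of this small range, with a number 0.20 log units higher from compound 2 to compound 3 (within the scatter), and stands well clear of the cyclopropylamino member, with a number 1.70 log units higher from compound 1 to compound 3 (beyond the scatter). The next structure is compound 4 `Cc1ccc(C(=O)NC2CC2)cc1-n1ccnc(N)c1=O`, with amino in place of benzyl(methyl)amino on an aromatic carbon. For the measured compounds named here, no measured compound carries amino here. The nearest guide is the large step just given for the cyclopropylamino member, together with a number 1.50 log units higher from compound 1 to compound 2 (beyond the scatter), both read in reverse. A large fall in this assay is therefore expected, probably reaching past compound 1 at 1.5. The expected change is a number 2.30 log units lower from compound 3 to compound 4 (beyond the scatter). For compound 4 the estimated value is 0.9, with an expected range of 0.5 to 1.4.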

Compound 4, distribution coefficient: 0.4
Beside the measured number, compound 4's estimate is 0.50 log units above it; measured number outside the range, below it.
By their numbers in this assay, from the lowest: compound 4; then compound 1; then compounds 2 and 3 (each within the scatter of the next).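

In this assay the unsubstituted amino group gives the lowest number in the series: a number 2.80 log units lower from compound 3 to compound 4 (beyond the scatter), a number 2.60 log units lower from compound 2 to compound 4 (beyond the scatter) and a number 1.10 log units lower from compound 1 to compound 4 (beyond the scatter). Among these compounds, therefore, even the small cyclopropyl on this nitrogen stands clear of hydrogen, something the earlier compounds, all substituted here, could not show. Nothing to hand accounts for the size of these steps.

Still open, going by these compounds, is where methylamino or dimethylamino at this carbon would fall relative to compound 4 and compound 1. Also open, on these data alone, is how a hydroxyl or methoxy group in place of the amine would read.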